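This account rests on a few compounds, and the source may have more. Where it says the series, first, only, none or still open, it means among the compounds named here.

Of the compounds shown here, two of one family have been measured in a functional assay on the whole organism (strain Wistar) with Rattus norvegicus as the target, with a stated time of 15 days, at a dose of 10 mg/kg by the oral route; on this read-out lower numbers stand for a weaker effect and higher numbers for a stronger effect at the one dose given. Compound 1 `O=C1NC(=O)/C(=C/c2ccc(OCCSc3nnc(-c4ccccc4)[nH]3)cc2)S1` gives 19.2%. Compound 2 `O=C1NC(=O)/C(=C/c2ccc(OCCSc3nnc(Cc4ccccc4)[nH]3)cc2)S1` gives 22.8%. Among the measured compounds shown here, the one step between them, a number 3.6 percentage points higher from compound 1 to compound 2 (within the scatter), arises from a benzyl in place of phenyl on an aromatic carbon and lies within the scatter, so compound 1 stands alongside compound 2 rather than apart from it.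

Compound 3 `COc1ccc(-c2nnc(SCCOc3ccc(/C=C4\SC(=O)NC4=O)cc3)[nH]2)cc1` is not yet measured. It differs from compound 1 by methoxy in place of hydrogen on an aromatic carbon. For the measured compounds named here, no measured step touches a methoxy group, so nothing directly bears on this change; the only step known, from a benzyl replacing a phenyl, stayed within the scatter. The expectation for compound 3 is therefore a step of a number 1.8 percentage points higher from compound 1 to compound 3 (within the scatter) in this assay, with no movement beyond the scatter in either direction. Compound 3 is estimated at 21%, within the range 10% to 34%.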

Compound 3, a percentage reported as activity, at one dose (the size of the read-out at that dose, not a potency): 42.6%
Estimate against measurement, compound 3: 21.6 percentage points below, outside the stated range (above it).
By their numbers in this assay, from the lowest: compounds 1 and 2 (each within the scatter of the next); then compound 3.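

In this assay, among the compounds shown here, methoxy in place of hydrogen, on an aromatic carbon para to a large group, gives a number 23.4 percentage points higher from compound 1 to compound 3 (beyond the scatter) and is the first step in this family to lie beyond the scatter. Going from benzyl to 4-methoxyphenyl gives a number 19.8 percentage points higher from compound 2 to compound 3 (beyond the scatter) and also lies beyond the scatter, so this end of the molecule can respond to a change even though the step from phenyl to benzyl stayed within the scatter. Nothing measured here offers a reason for the rise.

From the compounds shown here alone, it remains open whether a chlorine, a hydroxyl or a longer ethoxy group at the same place would raise the number as methoxy does, or whether methoxy on another carbon of that ring would count alike. With only one oral dose tested, these numbers also leave potency unsettled.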